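A few compounds are considered here, and "the series" means these few. Any claim that something is new, unique, unknown or untested is made for them only; others in the source may bear on it.

Measured so far:
Compound 1, `CC1(C)N=C(N)N=C(N)N1c1cccc(OCCCOc2ccc(S(=O)(=O)F)cc2)c1`: 7.96
Compound 2, `CC1(C)N=C(N)N=C(N)N1c1ccc(OCC(=O)Nc2cccc(S(=O)(=O)F)c2)c(Cl)c1`: 7.72

Both compounds were tested in an assay on isolated protein for inhibition of Dihydrofolate reductase (Mus musculus); a higher number here means a more potent compound, by a factor of ten per unit of this negative logarithm, a lower number a less potent compound. Of the two numbers, compound 2 gives the lower one, with 7.72, while compound 1 reaches 7.96. The gap between them is within the usual scatter of repeated measurements, so the two cannot be told apart on this basis, and neither can be called the more potent.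

Compound 3, `CC1(C)N=C(N)N=C(N)N1c1ccc(OCC(=O)Nc2ccc(S(=O)(=O)F)cc2)c(Cl)c1`, has not yet been measured. It has the same atoms as compound 2, joined differently: 4-(fluorosulfonyl)phenyl in place of 3-(fluorosulfonyl)phenyl on an amide-type nitrogen. Going by the values given here, no pair of measured compounds differs by this change alone, so no measured step shows what size of effect it brings. With nothing to point either way, the most reasonable expectation is a small step in this assay, not beyond the scatter, in either direction.

On that basis compound 3 is expected to give about 7.8 in this assay, with a likely range from 7.2 to 8.4. This estimate means a step of a number 0.08 log units higher from compound 2 to compound 3 (within the scatter), which is expected to stay within the scatter.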

Compound 3, logarithm of the reciprocal of the active concentration, log(1/C): 7.43
Beside the measured number, compound 3's estimate is 0.37 log units above it; the range from low to high includes it.
By their numbers in this assay, from the lowest: compounds 3, 2 and 1 (each within the scatter of the next, the first and the last beyond it).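

Going by these compounds alone, this is the first pair that differs in one place only, so it gives the first direct look at what this change does. With 4-(fluorosulfonyl)phenyl in place of 3-(fluorosulfonyl)phenyl on the amide-type nitrogen, this assay shows a number 0.29 log units lower from compound 2 to compound 3 (within the scatter) as the step, which means that the two compounds cannot be told apart on this measurement, and that for this pair, where the fluorosulfonyl group sits on the phenyl ring is not shown to matter. No separate measurement bears on this result, so nothing can be said about what lies behind it.

A single pair with the same chlorine-bearing core and the same amide-containing chain cannot show whether this small step would hold on another chain, such as a longer chain between the core and the amide, or on the core of compound 1. Nor do the compounds shown tell how much the fluorosulfonyl group itself contributes, which a phenyl group carrying a carboxylic acid or an amine in its place could begin to address.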